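A new amide substituent tested on the frame of compound 1

This account rests on a few compounds, and the source may have more. Where it says the series, first, only, none or still open, it means among the compounds named here.

Compound 1 `CC(C)(C)c1ccc(C(=O)N2CCC3(CC2)C(=O)N(CC(=O)N2CCN(S(C)(=O)=O)CC2)CN3c2ccccc2)cc1` was examined in an assay on HEK293 cells for displacement of a labelled ligand from NPC1-like intracellular cholesterol transporter 1 (Homo sapiens) (on this read-out higher numbers stand for weaker inhibition and lower numbers for stronger inhibition), where compound 1 gives 19000 nM. Among the three measured compounds, compound 1 has the highest number, yet only its gap to compound 2 is beyond the scatter: compound 2 `CS(=O)(=O)N1CCN(C(=O)CN2CN(c3ccccc3)C3(CCN(C(=O)c4ccc(C5CCCCC5)cc4)CC3)C2=O)CC1` gives 6300 nM, while compound 3 `O=C(CN1CN(c2ccccc2)C2(CCN(C(=O)c3ccc(C4CCCCC4)cc3)CC2)C1=O)NCCCCO` gives 10300 nM, and the gap between compound 1 and compound 3 lies within the scatter. The step of a 3.0-fold lower number from compound 1 to compound 2 (0.48 log units; beyond the scatter) is the single clear movement in the set.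

Compound 4 `CC(C)(C)c1ccc(C(=O)N2CCC3(CC2)C(=O)N(CC(=O)N2CCCCC2CO)CN3c2ccccc2)cc1` differs from compound 1 in one place: 2-(hydroxymethyl)piperidin-1-yl in place of 4-(methylsulfonyl)piperazin-1-yl on a carbonyl carbon. The step of a 1.6-fold higher number from compound 2 to compound 3 (0.21 log units; within the scatter) bears directly on this change, since it also removes the 4-(methylsulfonyl)piperazin-1-yl group from the same carbonyl carbon, and it stayed within the scatter. The step from compound 1 to compound 2 alters another part of the molecule and says nothing about this change. Compound 4 is therefore expected to remain close to compound 1, with perhaps a slight rise, a 1.2-fold higher number from compound 1 to compound 4 (0.08 log units; within the scatter). The estimate for compound 4 in this assay is 23000 nM, with a range from 9000 nM to 60000 nM.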

Compound 4, half-maximal inhibitory concentration: 11800 nM
The estimate for compound 4 lay 1.9-fold (0.29 log units) above the measured number; the measured number falls inside the stated range.
By their numbers in this assay, from the lowest: compounds 2, 3, 4 and 1 (each within the scatter of the next, the first and the last beyond it).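

In this assay, putting 2-(hydroxymethyl)piperidin-1-yl in place of 4-(methylsulfonyl)piperazin-1-yl on this carbonyl carbon gives a 1.6-fold lower number from compound 1 to compound 4 (0.21 log units; within the scatter). The earlier replacement at this carbonyl carbon had an open chain entering on the cyclohexyl frame; this one has a six-membered ring entering on the tert-butyl frame, so the 4-(methylsulfonyl)piperazin-1-yl group has now been exchanged on both frames without a step beyond the scatter. Nothing available bears on why this step is so small.

The compounds shown leave open whether a carboxylic acid or a primary amine on this carbonyl carbon would give a step beyond the scatter. They also leave open whether cyclohexyl in place of tert-butyl would give the same step on the frame of compound 4 as it does on that of compound 1.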